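The source may report more compounds than this note shows. Statements on the series, on what has been measured and on what is new or still open speak of the compounds shown alone.

The measured compounds in this study:
- compound 1, `O=C(Nc1cccc(F)c1)N[C@H]1CC[C@H](Oc2ccc(F)cc2)CC1`, gives 8300 nM in this series.
- compound 2, `O=C(Nc1ccccc1[N+](=O)[O-])N[C@H]1CC[C@H](Oc2ccc(F)cc2)CC1`, gives 3500 nM.
- compound 3, `O=C(Nc1ccc(Cl)cc1)N[C@H]1CC[C@H](Oc2ccc(F)cc2)CC1`, returned only a limit of the assay, > 20000 nM.

All three numbers come from a functional assay on CRL2813 cells (Homo sapiens) for cytotoxicity, read by sulforhodamine B assay, with a stated time of 5 days; on this read-out higher numbers stand for weaker inhibition and lower numbers for stronger inhibition. Of the two numbers given, compound 1 holds the higher; its nearest neighbour is compound 2, reached by a 2.4-fold lower number from compound 1 to compound 2 (0.38 log units; beyond the scatter). Compound 3 sits at a limit and gives no number, (the limit of > 20000 nM in this assay, at which 1 of the 3 values shown sits).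

Compound 4, `Cc1ccccc1NC(=O)N[C@H]1CC[C@H](Oc2ccc(F)cc2)CC1`, has not yet been measured. It differs from compound 1 in one place: 2-methylphenyl in place of 3-fluorophenyl on an amide-type nitrogen.

Going by the values given here, two measured steps bear on this change, since both alter the same aryl group on the same amide-type nitrogen. The step of a 2.4-fold lower number from compound 1 to compound 2 (0.38 log units; beyond the scatter) moved the number down by a modest margin, while the step of an at least 2.4-fold higher number from compound 1 to compound 3 (0.38 log units; beyond the scatter) moved it up, and the pair together gives an at least 5.7-fold higher number from compound 2 to compound 3 (0.75 log units; beyond the scatter). Neither step introduces a 2-methylphenyl, so the direction for compound 4 is not pinned down; the two steps point opposite ways and are each only modest.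

For compound 4 the expected value in this assay is therefore 8000 nM, with a range from 3000 nM to 20000 nM. That estimate amounts to a 1.0-fold lower number from compound 1 to compound 4 (0.02 log units; within the scatter), a step expected to stay within the scatter.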

Compound 4, half-maximal inhibitory concentration: > 20000 nM
Compound 4 gave a limit, no number; the forecaster's own chance of this, stated with the estimate: 15%; at least 2.5-fold (0.39 log units) between middle value and limit.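

In this assay the swap of nitro for methyl on the same aromatic carbon gives an at least 5.7-fold higher number from compound 2 to compound 4 (0.75 log units; beyond the scatter), so the stronger inhibition of compound 2 does not come with just any group there; among the compounds shown it goes with the nitro group alone. Measured against the parent, the change gives an at least 2.4-fold higher number from compound 1 to compound 4 (0.38 log units; beyond the scatter), which places 2-methylphenyl, like the 4-chlorophenyl of compound 3, on the weaker side of compound 1 and leaves 2-nitrophenyl as the only aryl group shown that lowers the number. Compound 3 and compound 4 both rest at a limit rather than a number, and the step between them cannot be read: the limit of > 20000 nM in this assay, at which 2 of the 4 values shown sit.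

Going by these compounds, whether a 2-chlorophenyl, a 2-cyanophenyl or a 2-aminophenyl on the amide-type nitrogen would side with compound 2 or with compound 4 remains open. Also open, on these data alone, is how far past the limit compound 3 and compound 4 really lie, and so whether these two differ from each other at all.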